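Hydroxyalkyl Amine Variations on the Shared Core

This account rests on a few compounds, and the source may have more. Where it says the series, first, only, none or still open, it means among the compounds named here.

Compound 3 `OCCCCCNCc1nc2c(OCC3CCCCC3)cccc2[nH]1` gives > 30000 nM in an assay on cells for inhibition of interleukin-5 receptor subunit alpha (Mus musculus), read by WST assay, with a stated time of 48 h, in the presence of a further agent that is not named here (a higher number here means a weaker inhibitor, a lower number a stronger inhibitor), which is a limit of the assay and not a number. Among the three measured values, compound 3 is the one that sits at the limit of > 30000 nM in this assay, at which 1 of the 3 values shown sits. Compound 1 `OCCNCc1nc2c(OCC3CCCCC3)cccc2[nH]1` gives 20000 nM and compound 2 `OCCCNCc1nc2c(OCC3CCCCC3)cccc2[nH]1` gives 28500 nM. The measured steps, a 1.4-fold higher number from compound 1 to compound 2 (0.15 log units; within the scatter), an at least 1.5-fold higher number from compound 1 to compound 3 (0.17 log units; that floor lies within the scatter) and an at least 1.0-fold higher number from compound 2 to compound 3 (0.02 log units; that floor lies within the scatter), all lie within the scatter. Compound 4 `CCC(CO)NCc1nc2c(OCC3CCCCC3)cccc2[nH]1` differs from compound 3 by 1-(hydroxymethyl)propyl in place of 5-hydroxypentyl on an amine nitrogen. For the measured compounds named here, no measured step covers a branched hydroxyalkyl group on the amine nitrogen; the steps seen only vary chain length and show no movement beyond the scatter. The expected step is therefore an at least 1.1-fold lower number from compound 3 to compound 4 (0.06 log units; that floor lies within the scatter). For compound 4 the estimated value is 26000 nM, within 9000 nM to 70000 nM.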

Compound 4, half-maximal inhibitory concentration: 3500 nM
For compound 4 the middle estimate is 7.4-fold (0.87 log units) above the measured one; measured number outside the range, below it.
By their numbers in this assay, from the lowest: compound 4; then compounds 1 and 2 (each within the scatter of the next). At a limit, above all of these: compound 3.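

In this assay, the amine nitrogen responds to branching as it did not to chain length across compounds 1, 2 and 3: 1-(hydroxymethyl)propyl in place of 3-hydroxypropyl gives an 8.1-fold lower number from compound 2 to compound 4 (0.91 log units; beyond the scatter). Ethyl in place of hydrogen on a saturated chain carbon bound to an amine nitrogen and a saturated chain carbon gives a 5.7-fold lower number from compound 1 to compound 4 (0.76 log units; beyond the scatter), so this added ethyl alone is enough for a step beyond the scatter. Against 5-hydroxypentyl the step is an at least 8.5-fold lower number from compound 3 to compound 4 (0.93 log units; beyond the scatter), and it is only a floor, since compound 3 stands at a limit of the assay and not a number: the limit of > 30000 nM in this assay, at which 1 of the 4 values shown sits.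

Open, going by these compounds, is whether methyl or propyl on that carbon does the same as ethyl. Also open, on these data alone, is whether the hydroxy group of compound 4 is needed, which a methoxy group in its place would address.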